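Benzotriazole amides: methoxy to nitro on the aroyl ring

The source may report more compounds than this note shows. Statements on the series, on what has been measured and on what is new or still open speak of the compounds shown alone.

Of the compounds shown here, two carry numbers so far. Compound 1 `Cc1cc2nnn(C(=O)c3ccccc3)c2cc1C` gives 3400 nM in an assay on isolated protein for inhibition of Alpha glucosidase (Homo sapiens) (a lower number here means a stronger inhibitor, a higher number a weaker inhibitor), and compound 2 `COc1ccc(C(=O)n2nnc3ccccc32)cc1` gives 2990 nM in this assay. Compound 2 holds the lower of the two numbers, but its nearest neighbour is compound 1 and the two values sit within the scatter of each other, so no order between them can be claimed. Among the measured compounds shown here, the pair differs in more than one place and no single step connects them.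

Compound 3 `O=C(c1ccc([N+](=O)[O-])cc1)n1nnc2ccccc21` is the next member awaiting measurement. Relative to compound 2 the change is nitro in place of methoxy on an aromatic carbon. Nothing in the measured pair bears on this exchange, so the step from compound 2 to compound 3 is expected to stay within the scatter, a 1.1-fold lower number from compound 2 to compound 3 (0.04 log units; within the scatter), with no direction favoured. Compound 3 is accordingly estimated at 2700 nM in this assay, within a range from 1000 nM to 7000 nM.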

Compound 3, half-maximal inhibitory concentration: 2970 nM
Compound 3: middle estimate off by 1.1-fold (0.04 log units), on the low side; the range from low to high includes it.
By their numbers in this assay, from the lowest: compounds 3, 2 and 1 (each within the scatter of the next).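

Nitro in place of methoxy on the aromatic carbon para to a large group gives a 1.0-fold lower number from compound 2 to compound 3 (0.00 log units; within the scatter) in this assay. Among the compounds shown here, this is the first single-place comparison, and compound 2 and compound 3 cannot be told apart in it. At this position, then, the two groups read alike despite differing in heavy atoms and hydrogen-bond acceptors, and nothing on hand indicates why.

Going by these compounds, whether an amine, a carboxylic acid or a longer chain at this same aromatic carbon would also stay within the scatter remains open. For the compounds shown here, compound 1 is still joined to the others by no single step, so the separate contributions of its differences from compound 2 and compound 3 cannot be read.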